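One stereocentre inverted: compound 3 to compound 4

The source may hold more compounds than are shown below. What is called first, only, known or untested is meant among the compounds shown, and "the series" means these compounds.

Compound 1 `CN1CCN(C2CCN(c3nccc4[nH]c(-c5ccc(F)c(F)c5)nc34)CC2)CC1` gives 5000 nM
Compound 2 `NCC1CCN(c2nccc3[nH]c(-c4cccc(OC(F)(F)F)c4)nc23)CC1` gives 2900 nM
Compound 3 `CN1CCN(C[C@@H]2CCCN(c3nccc4[nH]c(-c5cc(F)cc(F)c5)nc34)C2)CC1` gives 3200 nM

All three values come from an ADME assay on CHO cells (Cricetulus griseus) for cytotoxicity, read by MTT assay (on this read-out higher numbers stand for lower toxicity in this test and lower numbers for higher toxicity in this test), and lie within the usual scatter of one another. Compound 3 therefore stands level with the other two, and the numbers separate none of them.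

The next compound to be tested is compound 4 `CN1CCN(C[C@H]2CCCN(c3nccc4[nH]c(-c5cc(F)cc(F)c5)nc34)C2)CC1`, and its relation to compound 3 is simple: the two compounds have the same atoms and bonds and differ only in configuration as drawn: 1 of 1 stereo elements differ; a stereocentre at a saturated ring carbon is drawn S in compound 3 and R in compound 4. The two compounds have the same atoms and bonds, and a stereocentre at a saturated ring carbon is drawn S in compound 3 and R in compound 4.

Among the measured compounds shown here, no measured pair here differs only in configuration, so there is no direct guide to the size of such a change. For the measured compounds named here, the only anchor is compound 3 at 3200 nM, whose structure differs from compound 4 in this one respect. The expected result, a 1.0-fold higher number from compound 3 to compound 4 (0.01 log units; within the scatter), is no shift beyond the scatter in this assay, in either direction. For compound 4 the estimated value is 3300 nM, with an expected range from 1700 nM to 6300 nM as its bounds.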

Compound 4, half-maximal cytotoxic concentration in the CHO assay: 7900 nM
For compound 4 the middle estimate is 2.4-fold (0.38 log units) below the measured one; measured number outside the range, above it.
By their numbers in the CHO assay, from the lowest: compounds 2, 3, 1 and 4 (each within the scatter of the next, the first and the last beyond it).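

Among the compounds shown here, in the CHO assay, compound 3 gives 3200 nM and compound 4 gives 7900 nM; inverting this single stereocentre gives a 2.5-fold higher number from compound 3 to compound 4 (0.39 log units; beyond the scatter), the first step here that can be tied to one change, and it points towards lower toxicity in this test. The shift can be assigned to the configuration alone because nothing else differs: the fact that compounds 3 and 4 differ only in the configuration as drawn

In a physicochemical assay for solubility, read by HPLC, using the shake flask method, in phosphate buffer, with a stated time of 20 h, at pH 6.5 (a higher number here means a more soluble compound, a lower number a less soluble compound), compound 3 gives 145000 nM and compound 4 gives 200000 nM; the same inversion gives a 1.4-fold higher number from compound 3 to compound 4 (0.14 log units; within the scatter), so this read-out does not separate the two compounds.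

Going by these compounds, whether the step persists when the group on this stereocentre ends in a carboxylic acid rather than an amine remains open. A single pair also cannot show whether the R configuration gives higher numbers in general, or how the cells come to respond differently to the two compounds.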